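A few compounds are considered here, and "the series" means these few. Any claim that something is new, unique, unknown or untested is made for them only; others in the source may bear on it.

Compound 3 `Nc1nc2c(Cl)c(Cl)ccc2n1COCCO` is one of three close analogues tested in a functional assay on KB cells (Homo sapiens) for inhibition; on this read-out higher numbers stand for weaker inhibition and lower numbers for stronger inhibition. In this assay compound 3 gives no number but only a limit, > 100000 nM. Compound 1 `CNc1nc2cc(Cl)c(Cl)cc2n1COCCO` likewise reaches only a limit in this assay, > 100000 nM. Compound 2 `CN(C)c1nc2cc(Cl)c(Cl)cc2n1COCCO` also stops at a limit in this assay, > 100000 nM. Within the data shown here, the single step between measured compounds, a step that the two limits leave unreadable from compound 1 to compound 2, is unreadable for this reason, and compound 3 stands exactly where the others do: the limit of > 100000 nM in this assay, at which 3 of the 3 values shown sit. Compound 4 `OCCOCn1cnc2c(Cl)c(Cl)ccc21` differs from compound 3 by hydrogen in place of amino on an aromatic carbon. No readable measured step bears on this change, so nothing points to a gain or loss. Compound 4 is expected to stay at or near the limit, with an estimate of 200000 nM and a range from 50000 nM to 1000000 nM. The expected step from compound 3 is a step that the limit leaves unreadable from compound 3 to compound 4, no size beyond the scatter.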

Compound 4, half-maximal inhibitory concentration: > 100000 nM
Compound 4: only a limit was reported; the forecaster's own chance of this, stated with the estimate: 85%; the middle value is on the limit's open side.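

No new step can be read, since compound 3 and compound 4 both reach only a limit: the limit of > 100000 nM in this assay, at which 4 of the 4 values shown sit. The compounds shown leave open what change to the shared core, if any, would give a measurable value in this assay.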